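The source may hold more compounds than are shown below. What is called first, only, known or untested is meant among the compounds shown, and "the series" means these compounds.

Measured compounds, in an assay on isolated protein for inhibition of serine/threonine-protein kinase TBK1 (Homo sapiens); a lower number here means a stronger inhibitor, a higher number a weaker inhibitor:

compound 1 `O=C(CCc1ccccc1)NCCCNc1nc(Nc2cccc(F)c2)ncc1Br` — 560 nM
compound 2 `CC(C)n1cc(Nc2ncc(C3CC3)c(NCCCNC(=O)C3CCC3)n2)cn1` — 4 nM
compound 3 `O=C(NCCCNc1nc(Nc2ccc(-n3cncn3)cc2)ncc1C1CC1)C1CCC1` — 3 nM

Compound 1 stands highest of the three numbers in this assay. Its nearest neighbour is compound 2, whose value is lower by a gap beyond the scatter, and compound 3 sits lower still, also beyond the scatter. Within the data shown here, compounds 2 and 3 differ from compound 1 in more than one place at once, so no pair of measured compounds gives a clean single-point step, and the contribution of any one change cannot be read from the measured numbers alone.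

Compound 4 `COCCC(=O)NCCCNc1nc(Nc2cccc(F)c2)ncc1Br` is the unmeasured analogue of compound 1. The change is methoxy in place of phenyl on a saturated chain carbon, two bonds along the chain from a carbonyl carbon; cut one bond further out it reads phenethylcarbonyl to (2-methoxyethyl)carbonyl, so the amide cap becomes shorter and carries one acceptor where the phenyl carried none. Compounds 2 and 3 show that a small carbonyl cap is compatible with a low number in this assay, but they carry a different core, so they do not fix the direction here.

Without a measured step to lean on, the step from compound 1 to compound 4 is expected to be small, a 1.3-fold higher number from compound 1 to compound 4 (0.10 log units; within the scatter), within the scatter in either direction. Compound 4 is therefore estimated at 700 nM in this assay, with a range of 250 nM to 2000 nM.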

Compound 4, half-maximal inhibitory concentration: 60 nM
Beside the measured number, compound 4's estimate is 12-fold (1.07 log units) above it; the measured number lies below the stated range.
By their numbers in this assay, from the lowest: compounds 3 and 2 (each within the scatter of the next); then compound 4; then compound 1.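

In this assay, among these compounds, the step of a 9.3-fold lower number from compound 1 to compound 4 (0.97 log units; beyond the scatter) is the first clean single-point reading, and it comes from methoxy in place of phenyl on a saturated chain carbon, two bonds along the chain from a carbonyl carbon. It shows that the phenyl is not needed at this position for a lower number on the core of compound 1, and that phenethylcarbonyl can give way to (2-methoxyethyl)carbonyl, a cap with fewer heavy atoms and one hydrogen-bond acceptor where the phenyl carried none, with a gain beyond the scatter. Nothing measured here explains the step, and the loss of the ring and the gain of the acceptor remain unseparated.

Still open, as far as these compounds go, is whether the oxygen matters at all, which a plain propyl chain in the cap would test, and how an amine, a carboxylic acid or a longer ether chain would read at the same place. Also open, from the compounds shown here alone, is whether the same change would give a step of similar size on the core of compound 2, where the cap is already small.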